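A few compounds are considered here, and "the series" means these few. Any claim that something is new, unique, unknown or untested is made for them only; others in the source may bear on it.

Compound 1 `COc1ccc(C(=O)/C=C/c2cc(-c3cc(OC)c(OC)c(OC)c3)n[nH]2)cc1OC` gives the lowest number of the three measured compounds in a functional assay on NCI-H460 cells (Homo sapiens) for inhibition, read by sulforhodamine B assay, with a stated time of 48 h (on this read-out higher numbers stand for lower toxicity in this test and lower numbers for higher toxicity in this test), with 7860 nM. Compound 2 `COc1ccc(C(=O)/C=C/c2cc(-c3cc(OC)c(OC)c(OC)c3)n[nH]2)cc1` gives 8180 nM in this assay, and the change from compound 1 to compound 2 is a 1.0-fold higher number from compound 1 to compound 2 (0.02 log units; within the scatter). Compound 3 `COc1cc(-c2cc(/C=C/C(=O)c3ccc(F)c(F)c3)[nH]n2)cc(OC)c1OC` gives 80400 nM, and the step of a 10-fold higher number from compound 1 to compound 3 (1.01 log units; beyond the scatter) is large, as is a 9.8-fold higher number from compound 2 to compound 3 (0.99 log units; beyond the scatter).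

Compound 4 `COc1cc(C(=O)/C=C/c2cc(-c3cc(OC)c(OC)c(OC)c3)n[nH]2)cc(OC)c1OC` differs from compound 1 by methoxy in place of hydrogen on an aromatic carbon. The step that bears most directly on this change is a 1.0-fold higher number from compound 1 to compound 2 (0.02 log units; within the scatter), where a methoxy group on the same ring was removed with no effect beyond the scatter; the steps to compound 3 concern fluorine in place of methoxy and so speak less to the present change. Adding a methoxy group is therefore expected to leave the number close to that of compound 1, with no step beyond the scatter in this assay, so that a 1.0-fold lower number from compound 1 to compound 4 (0.02 log units; within the scatter) is the expected change. Compound 4 is estimated at 7500 nM, within a range from 3000 nM to 19000 nM.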

Compound 4, concentration lethal to 50% of the cells: 9910 nM
Beside the measured number, compound 4's estimate is 1.3-fold (0.12 log units) below it, within the range that was stated.
By their numbers in this assay, from the lowest: compounds 1, 2 and 4 (each within the scatter of the next); then compound 3.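

In this assay, within the data shown here, the earlier compounds showed only that a methoxy group could be taken away from this ring, whereas the step of a 1.3-fold higher number from compound 1 to compound 4 (0.10 log units; within the scatter) shows that one can also be added, on an aromatic carbon ortho to a methoxy group and meta to a large group. This addition also stays within the scatter, so in these compounds neither the removal nor the addition of a methoxy group moves the number measurably. Nothing available explains this lack of effect.

The compounds shown leave open whether a hydroxyl group, an amine or a single fluorine at this position would also stay within the scatter. They also leave open how much of the large step of a 10-fold higher number from compound 1 to compound 3 (1.01 log units; beyond the scatter) belongs to each of the two fluorines.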